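A few compounds are considered here, and "the series" means these few. Any claim that something is new, unique, unknown or untested is made for them only; others in the source may bear on it.

Compound 1 `O=C(NCCNc1nccc(-c2c(-c3cccc(F)c3)nc3sccn23)n1)c1c(F)cccc1F` carries a (2,6-difluorophenyl)carbonyl group on an amine nitrogen whose other neighbour is a saturated chain carbon. In a functional assay on SK-MEL-28 cells (Homo sapiens) for cytotoxicity, read by MTT assay (on this read-out lower numbers stand for stronger inhibition and higher numbers for weaker inhibition), compound 1 gives 11400 nM, the highest of the two numbers recorded, while compound 3 `O=S(=O)(NCCNc1nccc(-c2c(-c3cccc(F)c3)nc3sccn23)n1)c1ccc(C(F)(F)F)cc1` gives 8450 nM, which sits within the scatter of it. Compound 2 `Cc1ccc(S(=O)(=O)NCCNc2nccc(-c3c(-c4cccc(F)c4)nc4sccn34)n2)cc1` reaches only a limit in this assay, > 20000 nM. The step of an at least 1.7-fold higher number from compound 1 to compound 2 (0.24 log units; that floor lies within the scatter) therefore rests on (the limit of > 20000 nM in this assay, at which 1 of the 3 values shown sits), whereas an at least 2.3-fold lower number from compound 2 to compound 3 (0.37 log units; beyond the scatter) shows that trifluoromethyl in place of methyl on the aromatic carbon brings the number down again. Compound 4 `O=S(=O)(NCCNc1nccc(-c2c(-c3cccc(F)c3)nc3sccn23)n1)c1ccccc1` has not yet been measured; it differs from compound 1 in one place: phenylsulfonyl in place of (2,6-difluorophenyl)carbonyl on an amine nitrogen. Its phenylsulfonyl carries neither methyl nor trifluoromethyl, so the sulfonamides of compounds 2 and 3 bracket it. The step of a 1.3-fold higher number from compound 1 to compound 4 (0.12 log units; within the scatter) is expected to stay within the scatter, with some chance of a limit. Compound 4 is estimated at 15000 nM, between 7000 nM and 30000 nM.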

Compound 4, half-maximal inhibitory concentration: 19000 nM
The estimate for compound 4 lay 1.3-fold (0.10 log units) below the measured number; low and high end bracket the measured number.
By their numbers in this assay, from the lowest: compounds 3, 1 and 4 (each within the scatter of the next, the first and the last beyond it). At a limit, above all of these: compound 2.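

Taking the trifluoromethyl off the phenylsulfonyl matters on its own: in this assay there is a 2.2-fold higher number from compound 3 to compound 4 (0.35 log units; beyond the scatter), a modest step on this aromatic carbon. Exchanging the (2,6-difluorophenyl)carbonyl for phenylsulfonyl on the amine nitrogen gives a 1.7-fold higher number from compound 1 to compound 4 (0.22 log units; within the scatter), so this exchange stays within the scatter, even though the two groups differ in their linking unit and in their fluorine atoms. Hydrogen in place of methyl on the aromatic carbon gives an at least 1.0-fold lower number from compound 2 to compound 4 (0.02 log units; that floor lies within the scatter). Compound 2 stands at a limit, so this step cannot be read as a size: the limit of > 20000 nM in this assay, at which 1 of the 4 values shown sits.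

The compounds shown do not separate the fluorine atoms from the carbonyl, which a plain phenylcarbonyl group on the same nitrogen would do. They also leave open how a chlorine atom or a methoxy group on the phenylsulfonyl, or a longer chain, would read in this assay.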